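Compound 3 to compound 4: a change of amino group

This account rests on a few compounds, and the source may have more. Where it says the series, first, only, none or still open, it means among the compounds named here.

Compound 1 `CCn1c(C(=O)N(CCC#N)CCC#N)ccc1C(CC)(CC)c1ccc(OCCC(O)(CC)CC)c(C)c1`: 37800 nM
Compound 2 `C#CC(C)OC(=O)c1ccc(C(CC)(CC)c2ccc(OCCC(O)(CC)CC)c(C)c2)n1CC`: > 50000 nM (a limit)
Compound 3 `CCC(C)C(CO)NC(=O)c1ccc(C(CC)(CC)c2ccc(OCCC(O)(CC)CC)c(C)c2)n1CC`: > 50000 nM (a limit)

In an ADME assay on L02 cells (Homo sapiens) for antiproliferative activity, read by MTT assay, with a stated time of 48 h (on this read-out higher numbers stand for weaker inhibition and lower numbers for stronger inhibition), compound 3 gives > 50000 nM, which is a limit and not a number. It sits at the limit of > 50000 nM in this assay, at which 2 of the 3 values shown sit.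

Compound 4 `CCn1c(C(=O)N(C)CCO)ccc1C(CC)(CC)c1ccc(OCCC(O)(CC)CC)c(C)c1` carries (2-hydroxyethyl)(methyl)amino in place of (1-(hydroxymethyl)-2-methylbutyl)amino on a carbonyl carbon.

Three measured steps changed the group at this carbonyl carbon: an at least 1.3-fold higher number from compound 1 to compound 2 (0.12 log units; that floor lies within the scatter), an at least 1.3-fold higher number from compound 1 to compound 3 (0.12 log units; that floor lies within the scatter) and a step that the two limits leave unreadable from compound 2 to compound 3. Within the data shown here, none gives a readable size, and the only number is that of compound 1, at 37800 nM. No step beyond the scatter is therefore expected in this assay, and a further limit is quite possible.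

The expected step is a number no higher from compound 3 to compound 4 (the limit leaves the size open).

The estimated value for compound 4 is 50000 nM, with an expected range from 28000 nM to 90000 nM.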

Compound 4, half-maximal inhibitory concentration: 2050 nM
The estimate for compound 4 lay 24-fold (1.39 log units) above the measured number, and the stated range ends above it.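

In this assay, the group on the carbonyl carbon turns out to move the number well beyond the scatter, with (2-hydroxyethyl)(methyl)amino giving an at least 24-fold lower number from compound 3 to compound 4 (1.38 log units; beyond the scatter), an at least 24-fold lower number from compound 2 to compound 4 (1.38 log units; beyond the scatter) and an 18-fold lower number from compound 1 to compound 4 (1.27 log units; beyond the scatter). Among these compounds, the earlier changes at this carbonyl carbon gave no step of readable size, so this is the first large step at this position. Compound 4 stands clear of the limit that holds compound 2 and compound 3: the limit of > 50000 nM in this assay, at which 2 of the 4 values shown sit.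

Which part of the entering group matters stays open, the hydroxyl or the methyl. Going by these compounds, how a dimethylamino group or a (3-hydroxypropyl)(methyl)amino group would read at this carbonyl carbon is also open.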